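Ether side-chain changes on the shared core

The source may report more compounds than this note shows. Statements on the series, on what has been measured and on what is new or still open speak of the compounds shown alone.

compound 1 `CC(CC(C)(C)C)Oc1cccc2cccnc12` — > 2000 nM
compound 2 `CCC(C)COc1cccc2ccc(N)nc12` — 36 nM
compound 3 `Nc1ccc2cccc(OCC3CC4CCC3C4)c2n1` — 137 nM

In an assay on cells with melanin-concentrating hormone receptor 1 (Homo sapiens) as the target, read by radioligand binding (a lower number here means a stronger inhibitor, a higher number a weaker inhibitor), compound 2 gives 36 nM, the lowest of the two numbers, and compound 3 gives 137 nM, a higher number beyond the scatter. For compound 1 the value > 2000 nM is a limit of the assay, not a number (the limit of > 2000 nM in this assay, at which 1 of the 3 values shown sits).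

Compound 4 `Nc1ccc2cccc(OCC3CCCC3)c2n1` is not yet measured. It differs from compound 2 as follows: cyclopentyl in place of sec-butyl on a saturated chain carbon bound to an oxygen on an aromatic ring. For the measured compounds named here, no step between measured compounds of this kind is at hand, so a small step in this assay, toward a higher number or none beyond the scatter, is expected; compound 3 at 137 nM suggests a ring group still gives a number. Compound 4 is expected at 60 nM, between 20 nM and 200 nM. That estimate means an expected step of a 1.7-fold higher number from compound 2 to compound 4 (0.22 log units; within the scatter).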

Compound 4, half-maximal inhibitory concentration: 53 nM
Beside the measured number, compound 4's estimate is 1.1-fold (0.05 log units) above it; measured number inside the range.
By their numbers in this assay, from the lowest: compounds 2 and 4 (each within the scatter of the next); then compound 3. At a limit, above all of these: compound 1.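

For the compounds shown here, this is the first step between two measured compounds that differ in one place, and it can be read directly in this assay: a 1.5-fold higher number from compound 2 to compound 4 (0.17 log units; within the scatter). On this saturated chain carbon, then, cyclopentyl and sec-butyl cannot be told apart, so an open chain is not needed here for the number to hold. Nothing shown here bears on a cause for this step.

Open, as far as these compounds go, is whether a cyclohexyl ring, a longer chain or an amine at this place would stay within the scatter of compound 2 as well.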